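The source may hold more compounds than are shown below. What is called first, only, known or untested is meant among the compounds shown, and "the series" means these compounds.

Measured so far in a functional assay on HepG2 cells (Homo sapiens) for cytotoxicity, read by MTT assay, with a stated time of 72 h; on this read-out lower numbers stand for stronger inhibition and higher numbers for weaker inhibition:
Compound 1 `Nc1ccccc1NC(=O)c1ccc(NC(=S)NCc2cccc(F)c2)cc1`: 2900 nM
Compound 2 `Nc1ccccc1NC(=O)c1ccc(NC(=S)NCc2ccc(Cl)nc2)cc1`: 19000 nM
Compound 3 `Nc1ccccc1NC(=O)c1ccc(NC(=S)NCc2cncc(F)c2)cc1`: 13000 nM

The two pyridine compounds sit close together, with a 1.5-fold lower number from compound 2 to compound 3 (0.16 log units; within the scatter). The compound carrying 3-fluorophenyl lies apart, with a 4.5-fold higher number from compound 1 to compound 3 (0.65 log units; beyond the scatter) and a 6.6-fold higher number from compound 1 to compound 2 (0.82 log units; beyond the scatter). Compound 3 therefore stands well above the lowest number and level with the other pyridine.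

The unmeasured compound 4 `Cc1ccc(CNC(=S)Nc2ccc(C(=O)Nc3ccccc3N)cc2)cn1` keeps the shared core and changes one group: 6-methylpyridin-3-yl in place of 5-fluoropyridin-3-yl on a saturated chain carbon bound to an amide-type nitrogen. Here 6-methylpyridin-3-yl takes the place of 5-fluoropyridin-3-yl on a saturated chain carbon bound to an amide-type nitrogen.

Among the compounds with values here, no measured step makes exactly this swap. Within the data shown here, the closest guide is the one pyridine-for-pyridine exchange available, a 1.5-fold lower number from compound 2 to compound 3 (0.16 log units; within the scatter). The modest steps from compound 1 replace a phenyl ring, which does not happen here. So no step beyond the scatter is expected in this assay. The estimated step is a 1.1-fold higher number from compound 3 to compound 4 (0.03 log units; within the scatter). For compound 4 the expected value is 14000 nM, with an estimated range of 6000 nM to 30000 nM.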

Compound 4, half-maximal inhibitory concentration: 11000 nM
For compound 4 the middle estimate is 1.3-fold (0.10 log units) above the measured one; measured number inside the range.
By their numbers in this assay, from the lowest: compound 1; then compounds 4, 3 and 2 (each within the scatter of the next).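

In this assay, a methyl group on the pyridine gives a result level with the two halogen-bearing pyridines: a 1.2-fold lower number from compound 3 to compound 4 (0.07 log units; within the scatter), and a 1.7-fold lower number from compound 2 to compound 4 (0.24 log units; within the scatter). Compound 1 remains apart from this new pyridine as well, with a 3.8-fold higher number from compound 1 to compound 4 (0.58 log units; beyond the scatter), so all three pyridines shown, carrying fluoro, chloro or methyl, differ from the 3-fluorophenyl compound beyond the scatter. Nothing measured here explains this grouping.

On these data alone, it remains open whether a pyridine carrying an amine or a methoxy group, or no added group at all, would sit with these three compounds. Also open, as far as these compounds go, is whether a phenyl ring carrying methyl in place of the fluoro of compound 1 would stay near compound 1 or join the pyridines.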